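Swapping the aryl ring on a shared lactam core

A few compounds are considered here, and "the series" means these few. Any claim that something is new, unique, unknown or untested is made for them only; others in the source may bear on it.

Measured so far:
Compound 1, `O=C1/C(=C\c2cccc(Oc3ccccc3)c2)c2ccccc2N1c1c(Cl)cccc1Cl`: 5 ug/mL
Compound 2, `O=C1/C(=C\c2cccc(Br)c2)c2ccccc2N1c1c(Cl)cccc1Cl`: 2 ug/mL

Both compounds were tested in a functional assay on KB cells (Homo sapiens) for cytotoxicity, read by MTT assay, with a stated time of 72 h; a higher number here means that more compound is needed for the effect, a lower number that less compound is needed. Compound 2 has the lowest number of the two; its nearest neighbour is compound 1, and the step of a 2.5-fold lower number from compound 1 to compound 2 (0.40 log units; beyond the scatter) is modest but beyond the scatter. Compound 3, `O=C1/C(=C\c2ccc(Cl)cc2)c2ccccc2N1c1c(Cl)cccc1Cl`, has not been measured yet. It differs from compound 2 in one place: 4-chlorophenyl in place of 3-bromophenyl on a double-bonded chain carbon bound to a double-bonded ring carbon. Among the measured compounds shown here, no measured step changes exactly this part of the structure. For the measured compounds named here, the only step on record, a 2.5-fold lower number from compound 1 to compound 2 (0.40 log units; beyond the scatter), alters the same aromatic ring and shows that such edits move the number only modestly. On that loose basis, compound 3 is expected to stay close to compound 2, with the step of a 1.3-fold higher number from compound 2 to compound 3 (0.10 log units; within the scatter) expected to fall within the scatter. The estimate for compound 3 in this assay is therefore 2.5 ug/mL, within a range from 1 ug/mL to 6 ug/mL.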

Compound 3, concentration for half-maximal effect: 2 ug/mL
Compound 3: the middle estimate sits 1.3-fold (0.10 log units) above what was measured, within the range that was stated.
By their numbers in this assay, from the lowest: compounds 2 and 3 (each within the scatter of the next); then compound 1.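

In this assay, the step with no change at the digits printed from compound 2 to compound 3 (within the scatter) shows that this place on the shared core can take 4-chlorophenyl instead of 3-bromophenyl without any readable shift, whereas the earlier step changed a phenoxy group to a bromo group and did move the number. This single exchange alters both the halogen and the number in the ring's name, so it cannot show whether neither alteration matters or whether the two offset each other. No measurements are available to explain the flat result.

Among the compounds shown here, still open is how 4-bromophenyl and 3-chlorophenyl would compare, since each would alter only one part of this exchange. Also open, as far as these compounds go, is whether a ring carrying an amine or a carboxylic acid would stay close to compound 2 and compound 3.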